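The source may report more compounds than this note shows. Statements on the series, on what has been measured and on what is new or still open speak of the compounds shown alone.

Three compounds have a clearance reading in an ADME assay on liver for metabolic stability, with Liver microsome (Homo sapiens) as the target, read by LC-MS, using microsomes, with a stated time of 5 h (on this read-out higher numbers stand for fast clearance and lower numbers for slow clearance), so far. Compound 1 `O[C@@]1(c2ccccn2)CC[C@@H](c2ccc(C(F)(F)F)cc2)C1` gives 150 mL/min/kg and compound 2 `C[C@]1(c2ccc(OC(F)(F)F)cc2)C[C@@](O)(c2ccccn2)CO1` gives 117 mL/min/kg as well, two values that lie within the scatter of each other. Compound 3 `O[C@H](c1ccccn1)[C@]1(c2ccc(Cl)c(Cl)c2)CCO1` gives 66.7 mL/min/kg and so sits beyond the scatter on the slower side of compound 1. Compound 1 therefore stands with compound 2 at the fast-clearance end of this small set.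

Compound 4 `O[C@]1(c2ccccn2)CC[C@H](c2ccc(C(F)(F)F)cc2)C1` has yet to be measured in this assay and is closely tied to compound 1. The change from compound 1 is the two compounds have the same atoms and bonds and differ only in configuration as drawn: 2 of 2 stereo elements differ (all stereocentres are inverted: mirror images); a stereocentre at a saturated ring carbon is drawn S in compound 1 and R in compound 4; a stereocentre at a saturated ring carbon is drawn R in compound 1 and S in compound 4 and the two compounds are mirror images with the same atoms and bonds. Going by the values given here, no measured pair here shows what such an inversion does, so the size of the step cannot be read from the data. Among the compounds with values here, the expectation starts from compound 1 at 150 mL/min/kg and leans slightly towards compound 3 at 66.7 mL/min/kg as the only clearly slower reading. The step expected is a 1.2-fold lower number from compound 1 to compound 4 (0.08 log units; within the scatter) and this estimate stays within the scatter. For compound 4 the estimated clearance is 125 mL/min/kg with an expected range from 65 mL/min/kg to 210 mL/min/kg around that figure.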

Compound 4, clearance: 333 mL/min/kg
Beside the measured number, compound 4's estimate is 2.7-fold (0.43 log units) below it; measured number outside the range, above it.
By their numbers in this assay, from the lowest: compounds 3, 2 and 1 (each within the scatter of the next, the first and the last beyond it); then compound 4.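

In this assay, inverting both stereocentres of the shared core gives a 2.2-fold higher number from compound 1 to compound 4 (0.35 log units; beyond the scatter), so configuration as drawn carries a step beyond the scatter even though no atom or bond changes. The earlier compounds shown here could not show this: no two of them differ in one place, and their readings gave no measure of what any single change does. The step can be assigned to configuration alone, and to no change of group, for one plain reason: the fact that compounds 1 and 4 differ only in the configuration as drawn

Both stereocentres change together in this pair, so the compounds shown do not tell whether one of them alone carries the step or whether both contribute, and they do not tell whether the same inversion would move the number in the same direction on the other cores. Nor do they show whether the gap between the two mirror images would hold if the hydroxyl group gave way to an amine, or if the trifluoromethyl group gave way to a carboxylic acid.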